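Replacing bromo with phenyl on a thiourea-linked benzyl group

The source may hold more compounds than are shown below. What is called first, only, known or untested is meant among the compounds shown, and "the series" means these compounds.

The compounds share a thiourea core carrying a methanesulfonamide-bearing aryl group on one side. Compound 1 `CC(C)(C)c1ccc(C(C)(C)/N=C(\S)NCc2ccc(NS(C)(=O)=O)c(F)c2)cc1` is the exception in shape, and in an assay for inhibition of transient receptor potential cation channel subfamily V member 1 (Rattus norvegicus), with a stated time of 10 min (a lower number here means a stronger inhibitor, a higher number a weaker inhibitor), compound 1 gives only a limit of the assay, > 30000 nM (the limit of > 30000 nM in this assay, at which 1 of the 3 values shown sits). Compound 2 `CS(=O)(=O)Nc1ccc(C/N=C(\S)NCc2ccccc2)cc1F` gives 9700 nM in this assay. Compound 3 `CS(=O)(=O)Nc1ccc(C/N=C(\S)NCc2ccc(Br)cc2)cc1F` gives 570 nM in this assay, the lowest of the two numbers shown, and the single measured step, a 17-fold lower number from compound 2 to compound 3 (1.23 log units; beyond the scatter), shows how much adding a bromo changed the number.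

Compound 4 `CS(=O)(=O)Nc1ccc(C/N=C(\S)NCc2ccc(-c3ccccc3)cc2)cc1F` differs from compound 3 by phenyl in place of bromo on an aromatic carbon. Among the compounds with values here, the only step that bears on this change is the bromo-for-hydrogen step, which was large. Whether phenyl behaves like bromo is not known from these data, so compound 4 is expected to give a number of similar size to compound 3 in this assay, with wide uncertainty. Compound 4 is therefore estimated at 450 nM, within a range from 100 nM to 2500 nM, which means an expected step of a 1.3-fold lower number from compound 3 to compound 4 (0.10 log units; within the scatter).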

Compound 4, half-maximal inhibitory concentration: > 30000 nM
Compound 4: only a limit was reported; the forecaster's own chance of this, stated with the estimate: 5%; at least 66-fold (1.82 log units) between middle value and limit.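

At this place on the benzyl ring, the gain seen with bromo does not carry over to phenyl: in this assay, the swap gives an at least 52-fold higher number from compound 3 to compound 4 (1.72 log units; beyond the scatter). Phenyl also compares poorly with plain hydrogen, giving an at least 3.0-fold higher number from compound 2 to compound 4 (0.49 log units; beyond the scatter), so adding just any group here does not lower the number. Compound 4 reads only as a limit of the assay, so both steps are minimum sizes: the limit of > 30000 nM in this assay, at which 2 of the 4 values shown sit.

The compounds shown leave open how a chloro, a methyl or an amine at this place would compare with bromo. They also leave open whether the loss is particular to phenyl or would also come with a longer chain.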